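Adding a Methoxy Group to a Weak Inhibitor

The source may report more compounds than this note shows. Statements on the series, on what has been measured and on what is new or still open speak of the compounds shown alone.

Within the data shown here, compound 2 `Nc1cccc(-c2cn3c(-c4ccccc4)csc3n2)c1` gives 29000 nM in a functional assay on CCRF-CEM cells (Homo sapiens) for inhibition, read by cell counting, with a stated time of 3 days (a lower number here means a stronger inhibitor, a higher number a weaker inhibitor), the highest of the three numbers measured so far. Compound 1 `Nc1cccc(-c2cn3c(-c4ccc(Cl)cc4)csc3n2)c1` gives 21000 nM, and the step of a 1.4-fold higher number from compound 1 to compound 2 (0.14 log units; within the scatter) shows that swapping chloro for hydrogen on an aromatic carbon changed little. Compound 3 `C=C(Br)C(=O)Nc1cccc(-c2cn3c(-c4ccccc4)csc3n2)c1` gives 2800 nM; the step of a 10-fold lower number from compound 2 to compound 3 (1.02 log units; beyond the scatter) is large, but it concerns the nitrogen, not the aromatic ring. Compound 4 `COc1ccc(-c2csc3nc(-c4cccc(N)c4)cn23)cc1` has not yet been measured. It differs from compound 2 by methoxy in place of hydrogen on an aromatic carbon. Only the small step from compound 1 to compound 2 bears on such a change to an aromatic carbon, so no step beyond the scatter is expected. Compound 4 is therefore estimated at 25000 nM, within a range of 10000 nM to 60000 nM. The expected change a 1.2-fold lower number from compound 2 to compound 4 (0.06 log units; within the scatter) stays inside the usual scatter.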

Compound 4, half-maximal inhibitory concentration: 6100 nM
For compound 4 the middle estimate is 4.1-fold (0.61 log units) above the measured one, outside the stated range (below it).
By their numbers in this assay, from the lowest: compound 3; then compound 4; then compounds 1 and 2 (each within the scatter of the next).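

On this aromatic carbon, para to a large group, the substituent can matter after all: in this assay methoxy in place of hydrogen gives a 4.8-fold lower number from compound 2 to compound 4 (0.68 log units; beyond the scatter) and so moves beyond the scatter, which chloro did not do. Methoxy in place of chloro gives a 3.4-fold lower number from compound 1 to compound 4 (0.54 log units; beyond the scatter) as well, so these two groups are not interchangeable at this place. On these data alone, whether an ethoxy group, a longer chain, or an amine on this carbon would give a lower or a higher number remains open. Nothing measured here gives a reason for the methoxy result.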